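A few compounds are considered here, and "the series" means these few. Any claim that something is new, unique, unknown or untested is made for them only; others in the source may bear on it.

Compound 3 `COc1ccc(-c2ccc(C)n2-c2ccc(-c3nc4ccc(F)cc4s3)cc2)cc1` gives 37800 nM in an ADME assay on MCF-10A cells (Homo sapiens) for cytotoxicity, read by MTT assay, with a stated time of 72 h (a lower number here means a stronger inhibitor, a higher number a weaker inhibitor), level with compound 2 `Cc1ccc(-c2ccc(F)cc2)n1-c1ccc(-c2nc3ccc(F)cc3s2)cc1` at 37800 nM; compound 1 `Cc1ccc(-c2ccc([N+](=O)[O-])cc2)n1-c1ccc(-c2nc3ccccc3s2)cc1` at 38800 nM sits within the scatter of both, so the three numbers are indistinguishable. Compound 4 `Cc1ccc(-c2ccc([N+](=O)[O-])cc2)n1-c1ccc(-c2nc3ccc(F)cc3s2)cc1` differs from compound 3 by nitro in place of methoxy on an aromatic carbon. For the measured compounds named here, the only measured step, no change at the digits printed from compound 2 to compound 3 (within the scatter), lay within the scatter, and no measured step tests nitro in place of methoxy directly, though compound 1, the one that carries a 4-nitrophenyl group, is as weak as the rest in this assay. The step of a 1.0-fold higher number from compound 3 to compound 4 (0.00 log units; within the scatter) is therefore expected to stay within the scatter, with no clear direction. Compound 4 is estimated to give 38000 nM, with a range from 19000 nM to 76000 nM.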

Compound 4, half-maximal inhibitory concentration: 39000 nM
Compound 4: the middle estimate sits 1.0-fold (0.01 log units) below what was measured; measured number inside the range.
By their numbers in this assay, from the lowest: compounds 2, 3, 1 and 4 (each within the scatter of the next).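

Nitro in place of methoxy gives a 1.0-fold higher number from compound 3 to compound 4 (0.01 log units; within the scatter) and nitro in place of fluoro gives a 1.0-fold higher number from compound 2 to compound 4 (0.01 log units; within the scatter) in this assay and so, among these compounds, nitro, methoxy and fluoro on this aromatic carbon cannot be told apart. Fluoro in place of hydrogen on the core gives a 1.0-fold higher number from compound 1 to compound 4 (0.00 log units; within the scatter) and is equally within the scatter, so this change also leaves the number unmoved in this pair. No evidence bears on why these numbers coincide. From the compounds shown here alone, whether an amine or a carboxylic acid on this aromatic carbon would shift the number beyond the scatter stays open.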